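This account rests on a few compounds, and the source may have more. Where it says the series, first, only, none or still open, it means among the compounds named here.

Measured so far: compound 1 `Clc1ccc(Oc2cncc(C3=CC4CNCC(C3)C4)c2)cc1`, 1.9 nM; compound 2 `Clc1cccc(Oc2cncc(C3=CC4CNCC(C3)C4)c2)c1`, 1 nM.

In an in vitro assay on SH-EP1 cells for displacement of a labelled ligand from Neuronal acetylcholine receptor; alpha4/beta2 (Homo sapiens) (on this read-out lower numbers stand for stronger inhibition and higher numbers for weaker inhibition), compound 2 gives the lowest of the two numbers, but the step of a 1.9-fold lower number from compound 1 to compound 2 (0.28 log units; within the scatter) lies within the scatter, so the two compounds cannot be separated. Compound 3 `COc1ccc(Oc2cncc(C3=CC4CNCC(C3)C4)c2)cc1` carries 4-methoxyphenyl in place of 3-chlorophenyl on an oxygen on an aromatic ring. Among the measured compounds shown here, no measured step bears directly on this exchange; the only step recorded swaps 4-chlorophenyl for 3-chlorophenyl and stays within the scatter. A modest rise in the number is therefore expected, with the expected step being a 3.0-fold higher number from compound 2 to compound 3 (0.48 log units; beyond the scatter). Compound 3 is estimated at 3 nM, within a range from 0.8 nM to 12 nM.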

Compound 3, inhibition constant: 1.4 nM
For compound 3 the middle estimate is 2.1-fold (0.33 log units) above the measured one, within the range that was stated.
By their numbers in this assay, from the lowest: compounds 2, 3 and 1 (each within the scatter of the next).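

In this assay, methoxy in place of chloro on an aromatic carbon reads as a 1.4-fold lower number from compound 1 to compound 3 (0.13 log units; within the scatter), and 4-methoxyphenyl in place of 3-chlorophenyl on an oxygen on an aromatic ring reads as a 1.4-fold higher number from compound 2 to compound 3 (0.15 log units; within the scatter). Neither exchange separates the compounds, so at this position a 4-methoxyphenyl with its hydrogen-bond acceptor cannot be told apart from either chlorophenyl. Nothing available explains this result.

The compounds shown leave open how an amine or a carboxylic acid on this aromatic ring would read. They also leave open whether a longer chain in place of methoxy would stay within the scatter of compound 3.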